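Extending the Shared Core of Compound 3 with an Amide Ether

A few compounds are considered here, and "the series" means these few. Any claim that something is new, unique, unknown or untested is made for them only; others in the source may bear on it.

Compound 3 `Oc1cc2ccccc2cc1C(O)(C(F)(F)F)C(F)(F)F` is the bare core of this small set. In an assay on isolated protein for inhibition of receptor-type tyrosine-protein phosphatase C (Homo sapiens), read by spectrophotometry (on this read-out higher numbers stand for weaker inhibition and lower numbers for stronger inhibition), compound 3 gives 112000 nM, the highest of the two numbers reported, and its neighbour is compound 1 `Cc1ccc(S(=O)(=O)NNC(=O)COc2ccc3cc(C(O)(C(F)(F)F)C(F)(F)F)c(O)cc3c2)cc1`, which in this assay gives 16100 nM. Compound 2 `O=C(COc1ccc2cc(C(O)(C(F)(F)F)C(F)(F)F)c(O)cc2c1)Nc1ccccc1` reaches only a limit of this assay, > 20000 nM; the limit of > 20000 nM in this assay, at which 1 of the 3 values shown sits, marks that limit. Within the data shown here, the single step measured between substituted compounds, an at least 1.2-fold higher number from compound 1 to compound 2 (0.09 log units; that floor lies within the scatter), is small enough to sit within the scatter. Compound 4 `O=C(COc1ccc2cc(C(O)(C(F)(F)F)C(F)(F)F)c(O)cc2c1)NC1CC1` has not yet been measured in this assay; it differs from compound 3 by (cyclopropylcarbamoyl)methoxy in place of hydrogen on an aromatic carbon. The group entering in compound 4 resembles those carried by compound 1 and compound 2, both of which lie well below the number of compound 3, so a clearly lower number than compound 3 is expected, while the distance between compound 1 and compound 2 leaves the exact size of the gain uncertain. Compound 4 is therefore expected to show a step of a 4.5-fold lower number from compound 3 to compound 4 (0.65 log units; beyond the scatter) in this assay. The estimate for compound 4 is 25000 nM, within a range from 8000 nM to 80000 nM.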

Compound 4, half-maximal inhibitory concentration: > 20000 nM
Compound 4: no number, only a limit; the forecaster's own chance of this, stated with the estimate: 30%; the middle value does not contradict the limit.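

For compound 4, this assay gives only a limit, > 20000 nM, and not a number. Among these compounds, the one step that can be read, an at least 1.2-fold higher number from compound 1 to compound 4 (0.09 log units; that floor lies within the scatter), comes with cyclopropyl in place of ((4-methylphenyl)sulfonyl)amino on the amide-type nitrogen, so it sets no order between the two compounds. The steps to compound 4 from compound 3 and from compound 2 cannot be read, and with cyclopropyl in compound 4 joining phenyl in compound 2, a second group on that nitrogen now ends at the assay limit, leaving compound 1 as the only compound with this side chain that gives a number: the limit of > 20000 nM in this assay, at which 2 of the 4 values shown sit.

Going by these compounds, whether the (cyclopropylcarbamoyl)methoxy group brings compound 4 any real gain over the bare core of compound 3 remains open, as does how far compound 4 and compound 2 actually lie from compound 1. Also open, on these data alone, is how the series would read with an amine or a carboxylic acid on the amide-type nitrogen in place of cyclopropyl, or with a longer chain between the ether oxygen and the carbonyl.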